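The compounds below may be only part of what the source reports. "The series", "measured", "known", "first", "only" and "open" are said of these compounds alone.

Working notes on the oxazinone series.

Compound 1 `O=C1COc2ccc(-c3cccc(NS(=O)(=O)c4ccc(F)cc4)c3)cc2N1c1ccc(Cl)cc1` is the reference point; in a functional assay on MCF7 cells (Homo sapiens) for antiproliferative activity, read by MTT assay, with a stated time of 72 h (a lower number here means a stronger inhibitor, a higher number a weaker inhibitor), compound 1 gives 39800 nM. Compound 2 `O=C1COc2ccc(-c3cccc(NS(=O)(=O)c4ccc(F)cc4)c3)cc2N1c1ccccc1` is its counterpart with hydrogen in place of chloro on an aromatic carbon. In this assay compound 2 gives only a limit of the assay, > 40000 nM, and not a number. Going by these compounds, the step of a number no lower from compound 1 to compound 2 (the limit leaves the size open) is therefore known only in direction, and its size stays open because compound 2 sits at the limit of > 40000 nM in this assay, at which 1 of the 3 values shown sits.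

Compound 3 `O=C1COc2ccc(-c3cnc(Cl)c(NS(=O)(=O)c4ccc(F)cc4)c3)cc2N1c1ccc(Cl)cc1` carries a different core; the difference between the core of compound 3 and the core of compound 1 is not broken down here. In this assay compound 3 gives 32800 nM, a number within the scatter of that of compound 1, so no order between compound 3 and compound 1 can be read.

Compound 4 `O=C1COc2ccc(-c3cnc(Cl)c(NS(=O)(=O)c4ccc(F)cc4)c3)cc2N1c1ccccc1` is not yet measured in this assay. It stands to compound 3 as compound 2 stands to compound 1, with hydrogen in place of chloro on an aromatic carbon; the place of the change is the same in both pairs, so it is the same change on a second core. Given that the same change gave a number no lower from compound 1 to compound 2 (the limit leaves the size open), the step of a 1.4-fold higher number from compound 3 to compound 4 (0.14 log units; within the scatter) is expected to go the same way, toward a number no lower than that of compound 3. For compound 4 in this assay the estimate is 45000 nM, with a range from 25000 nM to 100000 nM, and a real chance that, like compound 2, compound 4 returns only a limit of the assay.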

Compound 4, half-maximal inhibitory concentration: > 40000 nM
Compound 4 ended at the assay's limit (the forecaster's own chance of this, stated with the estimate: 60%); the middle value is on the limit's open side.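

Replacing chloro with hydrogen on the 4-chlorophenyl group of the second core gives, in this assay, an at least 1.2-fold higher number from compound 3 to compound 4 (0.08 log units; that floor lies within the scatter), and the floor of this step does not by itself separate compound 4 from compound 3. Compound 4 gives a limit of the assay and not a number, as compound 2 does, so the size of neither step can be read and both pairs stop at the same ceiling: the limit of > 40000 nM in this assay, at which 2 of the 4 values shown sit. The two pairs show that going from 4-chlorophenyl to phenyl gave no lower number on either core, but they do not show that the change carries over with the same size, or that its size on either core lies beyond the scatter: the same change on two cores in this assay, a number no lower (the limit leaves the size open) from compound 1 to compound 2 and an at least 1.2-fold higher number (0.08 log units; that floor lies within the scatter) from compound 3 to compound 4; the limit leaves it open whether they differ.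

The compounds shown leave open whether another group in place of the chloro, such as methoxy, an amine or a carboxylic acid, would give a lower number on either core. Also open, going by these compounds, is the real size of both steps, which would take numbers in place of the limits for compound 2 and compound 4.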